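Smaller Branching on the Amino Acid Side Chain

The compounds below may be only part of what the source reports. "The series", "measured", "known", "first", "only" and "open" are said of these compounds alone.

Of the compounds shown here, two sharing one core have been tested in an assay on isolated protein for inhibition of Rho-associated protein kinase 2 (Homo sapiens); a lower number here means a stronger inhibitor, a higher number a weaker inhibitor. Compound 1 `O=C(Nc1cc2cc[nH]c(=O)c2cc1Cl)[C@@H]1CCCN1` carries pyrrolidin-2-yl on the carbonyl carbon, and in this assay compound 1 gives 35 nM. Among the measured compounds shown here, compound 2 `CC(C)(C)C[C@H](N)C(=O)Nc1cc2cc[nH]c(=O)c2cc1Cl` carries 1-amino-3,3-dimethylbutyl in that place, and in this assay compound 2 gives 845 nM, the higher of the two numbers measured; the one step recorded, a 24-fold higher number from compound 1 to compound 2 (1.38 log units; beyond the scatter), separates it from compound 1. Compound 3 `CC(C)C[C@@H](N)C(=O)Nc1cc2cc[nH]c(=O)c2cc1Cl` is the next compound, differing from compound 2 as follows: 1-amino-3-methylbutyl in place of 1-amino-3,3-dimethylbutyl on a carbonyl carbon. For the measured compounds named here, no measured step bears directly on this change; the only step available concerns the swap of pyrrolidin-2-yl for 1-amino-3,3-dimethylbutyl, a larger rearrangement than the present one. Only a small shift toward a lower number is therefore expected, a 1.7-fold lower number from compound 2 to compound 3 (0.23 log units; within the scatter). Compound 3 is estimated to give 500 nM, within a range from 150 nM to 1500 nM.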

Compound 3, half-maximal inhibitory concentration: 19 nM
Compound 3: middle estimate off by 26-fold (1.42 log units), on the high side, outside the stated range (below it).
By their numbers in this assay, from the lowest: compounds 3 and 1 (each within the scatter of the next); then compound 2.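

In this assay the high number of compound 2 turns out not to follow from losing the ring of compound 1, since the open-chain 1-amino-3-methylbutyl shows only a 1.8-fold lower number from compound 1 to compound 3 (0.27 log units; within the scatter) and so stays within the scatter. The position is instead very sensitive to the end of the chain: one carbon fewer goes with a 44-fold lower number from compound 2 to compound 3 (1.65 log units; beyond the scatter) and is a large step. No measurement here explains why so small a change has so large an effect.

The structures of compound 2 and compound 3 are also drawn with opposite handedness at the stereocentre. The data do not separate the chain from that centre in the step between these two compounds. From the compounds shown here alone, how a shorter chain such as 1-aminoethyl or 1-amino-2-methylpropyl would fare at this position also remains open.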